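Swapping a Chloro for a Methoxy

This account rests on a few compounds, and the source may have more. Where it says the series, first, only, none or still open, it means among the compounds named here.

Compound 1 `c1ccc(-c2nc3ccc[nH]c-3n2)cc1`: 8 mg/kg
Compound 2 `Clc1ccc(-c2nc3cc[nH]cc-3n2)c(Cl)c1`: 0.7 mg/kg

The measure here is a functional assay on the whole organism with Canis familiaris (Canis lupus familiaris) as the target; on this read-out higher numbers stand for an effect only at larger amounts of compound and lower numbers for an effect already at smaller amounts. Compound 2, at 0.7 mg/kg, has the lower of the two numbers, so it acts at a smaller dose than compound 1 at 8 mg/kg, and this gap lies beyond the scatter. The two compounds differ in more than one place, so their gap says nothing about any single change.

The next compound is compound 3 `COc1cc(Cl)ccc1-c1nc2cc[nH]cc-2n1`, which carries methoxy in place of chloro on an aromatic carbon. The remaining chloro group and the shared core stay unchanged. Within the data shown here, no measured pair here shows this swap, so the expectation in this assay is only a small shift toward a lower number, none beyond the scatter. The expected change is a 1.8-fold lower number from compound 2 to compound 3 (0.24 log units; within the scatter). For compound 3 the estimated value is 0.4 mg/kg, with an expected range from 0.1 mg/kg to 1.5 mg/kg.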

Compound 3, dose for half-maximal effect: 0.23 mg/kg
Estimate against measurement, compound 3: 1.7-fold (0.24 log units) above; measured number inside the range.
By their numbers in this assay, from the lowest: compound 3; then compound 2; then compound 1.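

In this assay, putting methoxy in place of chloro gives a 3.0-fold lower number from compound 2 to compound 3 (0.48 log units; beyond the scatter). Among these compounds, this is the first change in the set made at a single place, so it shows that the group on this aromatic carbon, ortho to a group of 9 heavy atoms, affects the dose needed, and that chloro is not required there for a low number. No separate measurement bears on why the number falls.

A single swap cannot show whether the shift would continue with a longer chain such as ethoxy, or whether an amine on the same carbon would keep the low number. It also leaves open how much the remaining chloro group, meta to this position, contributes to the effect.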